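Swapping Hydroxy for Ethylamino on the Strongest Compound

A few compounds are considered here, and "the series" means these few. Any claim that something is new, unique, unknown or untested is made for them only; others in the source may bear on it.

In a functional assay on A549 cells (Homo sapiens) for antiproliferative activity, read by MTT assay, with a stated time of 48 h (on this read-out higher numbers stand for weaker inhibition and lower numbers for stronger inhibition), compound 1 (`COc1ccc(C(=O)c2ccc3c(c2)C=CC(C)(C)O3)c(NC(=O)CN)c1`) gives 310 nM while compound 2 (`CNCC(=O)Nc1cc(OC)ccc1C(=O)c1ccc(OC)c2c1OC(C)(C)C=C2`) gives 620 nM and compound 3 (`C=C(c1ccc(OC)cc1NC(=O)CO)c1ccc(OC)c2c1C=CC(C)(C)O2`) gives 70 nM as the lowest number of the three. Its gap to each of the others lies beyond the usual scatter, so compound 3 is the strongest inhibitor measured so far.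

One change, ethylamino in place of hydroxy on a saturated chain carbon bound to a carbonyl carbon with ethylamino in place of hydroxy on a saturated chain carbon bound to a carbonyl carbon, turns compound 3 into compound 4 (`C=C(c1ccc(OC)cc1NC(=O)CNCC)c1ccc(OC)c2c1C=CC(C)(C)O2`). Going by the values given here, no measured pair shows this swap on its own. Compound 1 at 310 nM and compound 2 at 620 nM carry nitrogen groups on that chain carbon, but both also differ from compound 3 elsewhere, so they offer only a loose guide. They still point towards a moderate weakening in this assay that is expected to lie just beyond the scatter. The expected size is a 2.6-fold higher number from compound 3 to compound 4 (0.41 log units; beyond the scatter) on this estimate. The estimate for compound 4 is 180 nM (expected range 60 nM to 600 nM).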

Compound 4, half-maximal inhibitory concentration: 1870 nM
Compound 4: middle estimate off by 10-fold (1.02 log units), on the low side; measured number above the stated range.
By their numbers in this assay, from the lowest: compound 3; then compounds 1 and 2 (each within the scatter of the next); then compound 4.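

Going by these compounds alone, this swap gives the first clean reading of the saturated chain carbon bound to a carbonyl carbon. With hydroxy replaced by ethylamino and nothing else changed, this assay shows a 27-fold higher number from compound 3 to compound 4 (1.43 log units; beyond the scatter), so what this carbon carries matters greatly on this core. The counts of hydrogen-bond donors and acceptors stay the same while the group grows by a few heavy atoms. Nothing available here explains the loss.

Going by these compounds, it remains open whether the loss follows the nitrogen or the two added carbons, and an ethoxy group on that same carbon would keep the oxygen while carrying those carbons. Also open, on these data alone, is how a dimethylamino group there would compare with ethylamino on the core of compound 3.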